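Tert-butyl in place of trifluoromethyl on the shared core

A few compounds are considered here, and "the series" means these few. Any claim that something is new, unique, unknown or untested is made for them only; others in the source may bear on it.

Measured so far in a toxicity assay on Vero C1008 cells (Chlorocebus sabaeus) for cytotoxicity, read by MTT assay, with a stated time of 48 h; a higher number here means that more compound is tolerated, a lower number that less compound is tolerated
compound 1 `O=C(Nc1cccc(Cl)c1)c1cc(Cl)ccc1O` gives 2460 nM
compound 2 `O=C(Nc1cccc(F)c1)c1cc(Cl)ccc1O` gives 3630 nM
compound 3 `O=C(Nc1cccc(C(F)(F)F)c1)c1cc(Cl)ccc1O` gives 5950 nM

Compound 3 has the highest number of the three, but its lead is small. The step of a 1.6-fold higher number from compound 2 to compound 3 (0.21 log units; within the scatter) does not clear the scatter, and only the modest step of a 2.4-fold higher number from compound 1 to compound 3 (0.38 log units; beyond the scatter) does.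

Compound 4 `CC(C)(C)c1cccc(NC(=O)c2cc(Cl)ccc2O)c1` has tert-butyl in place of trifluoromethyl on an aromatic carbon. Among the compounds with values here, no measured compound carries tert-butyl, so the only guide is the other exchanges at this place on the core: a 1.5-fold higher number from compound 1 to compound 2 (0.17 log units; within the scatter), together with the two steps above. All three are small, and the largest is modest. In this assay a small step is therefore expected, leaning downward from compound 3 and not beyond the scatter. The expected change is a 1.5-fold lower number from compound 3 to compound 4 (0.17 log units; within the scatter) as an estimate. For compound 4 the estimated value is 4000 nM, with an expected range from 1800 nM to 9000 nM as the bounds.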

Compound 4, half-maximal cytotoxic concentration: 2360 nM
For compound 4 the middle estimate is 1.7-fold (0.23 log units) above the measured one; the measured number falls inside the stated range.
By their numbers in this assay, from the lowest: compounds 4, 1, 2 and 3 (each within the scatter of the next, the first and the last beyond it).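

In this assay the exchange of trifluoromethyl for tert-butyl gives a 2.5-fold lower number from compound 3 to compound 4 (0.40 log units; beyond the scatter) and so shows that a non-halogen group at this position can also separate from trifluoromethyl by more than the scatter. Compound 3 now stands apart from both compound 1 and compound 4, though not from compound 2. Tert-butyl does not separate from either halogen, with a 1.5-fold lower number from compound 2 to compound 4 (0.19 log units; within the scatter) and a 1.0-fold lower number from compound 1 to compound 4 (0.02 log units; within the scatter) both within the scatter, and nothing measured here bears on the reason for these steps.

Going by these compounds, whether an amine or a carboxylic acid at this position would take the number outside the band set by these four groups remains open. Also open, on these data alone, is whether the same order would hold with a longer chain here or with a change elsewhere on the shared core.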